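Replacing cyclopentenyl with a carboxyfuran group

The compounds below may be only part of what the source reports. "The series", "measured", "known", "first", "only" and "open" are said of these compounds alone.

Of the compounds shown here, three have been measured in an ADME assay on microsomes from liver (Rattus norvegicus) for metabolic stability; on this read-out higher numbers stand for a longer-lived compound and lower numbers for a shorter-lived compound. Compound 1 `CNCc1ccc(-c2c3ncn(CC4(O)CCN(Cc5ccc(-c6ccco6)cc5Cl)CC4)c(=O)c3nn2C)cc1` gives 0.533 h, and compound 2 `Cn1nc2c(=O)n(CC3(O)CCN(Cc4ccc(-c5ccco5)cc4Cl)CC3)cnc2c1-c1ccc(CNS(C)(=O)=O)cc1` gives 0.433 h. Compound 3 `Cn1nc2c(=O)n(CC3(O)CCN(Cc4ccc(C5=CCCC5)cc4Cl)CC3)cnc2c1-c1ccc(CN)cc1` gives 2.33 h, the highest of the three and beyond the usual scatter from both others.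

Compound 4 `Cn1nc2c(=O)n(CC3(O)CCN(Cc4ccc(-c5ccc(C(=O)O)o5)cc4Cl)CC3)cnc2c1-c1ccc(CN)cc1` has 5-carboxyfuran-2-yl in place of cyclopent-1-en-1-yl on an aromatic carbon.

For the measured compounds named here, the only measured single-place step, a 1.2-fold lower number from compound 1 to compound 2 (0.09 log units; within the scatter), concerns a different part of the molecule, so it says little about this change. Compound 1 and compound 2 also hold a five-membered aromatic ring at this place, without the carboxy group, and both stand lower than compound 3. They differ from compound 3 elsewhere too, which makes this a weak hint.

In this assay, the expected change is a drop slightly beyond the scatter, estimated as a 2.3-fold lower number from compound 3 to compound 4 (0.37 log units; beyond the scatter). Compound 4 is estimated at 1 h, within an expected range of 0.4 h to 3 h.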

Compound 4, half-life: 1.25 h
Estimate against measurement, compound 4: 1.3-fold (0.10 log units) below; measured number inside the range.
By their numbers in this assay, from the lowest: compounds 2 and 1 (each within the scatter of the next); then compounds 4 and 3 (each within the scatter of the next).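

For the compounds shown here, this is the first step that changes only this position. In this assay, 5-carboxyfuran-2-yl replaces cyclop-1-en-1-yl on the aromatic carbon (a 1.9-fold lower number from compound 3 to compound 4 (0.27 log units; within the scatter)). The swap brings in a larger group with three oxygen atoms, a hydrogen-bond donor and hydrogen-bond acceptors, yet the two half-lives cannot be told apart, so at this position such a large change in the group does not show up as a clear change on this read-out. Nothing at hand explains this result.

Still open, on these data alone, is whether a primary amide, a methyl ester or a plain phenyl ring at this position would also stay within the scatter of compound 3. Also open is how much of this outcome comes from the furan ring and how much from its carboxy group, since the shared core with the aminomethyl group is shown here with only these two groups.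

Correction to the group name above: the departing group is cyclopent-1-en-1-yl.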